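The source may hold more compounds than are shown below. What is called first, only, known or untested is meant among the compounds shown, and "the series" means these compounds.

Measured compounds:
Compound 1 `COc1cccc(COc2ccc(-c3nn(CCC#N)c(=S)o3)cc2)c1` gives 100 nM in an assay for inhibition of Amine oxidase [flavin-containing] B (Rattus norvegicus); a higher number here means a weaker inhibitor, a lower number a stronger inhibitor.
Compound 2 `Cc1ccc(COc2ccc(-c3nn(CCC#N)c(=S)o3)cc2)cc1` gives 400 nM in this assay.
Compound 3 `N#CCCn1nc(-c2ccc(OCc3cccc(Cl)c3)cc2)oc1=S` gives 160 nM in this assay.

For the measured compounds named here, compound 3 holds the second highest of the three numbers, but its gap to compound 1, a 1.6-fold higher number from compound 1 to compound 3 (0.20 log units; within the scatter), sits within the scatter; only the step of a 2.5-fold lower number from compound 2 to compound 3 (0.40 log units; beyond the scatter) lies beyond it. Compound 4 `N#CCCn1nc(-c2ccc(OCc3ccc(Cl)cc3)cc2)oc1=S` differs from compound 3 in the benzyl group alone: 4-chlorophenyl in place of 3-chlorophenyl on a saturated chain carbon bound to an oxygen on an aromatic ring.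

Two measured steps exchange the group on the saturated chain carbon bound to an oxygen on the aromatic ring, a 4.0-fold higher number from compound 1 to compound 2 (0.60 log units; beyond the scatter) and a 2.5-fold lower number from compound 2 to compound 3 (0.40 log units; beyond the scatter). Each changes the ring substituent together with its place, so neither isolates the shift from 3-chlorophenyl to 4-chlorophenyl. Still, the 4-methylphenyl compound 2 carries the highest number, and a 1.6-fold higher number from compound 1 to compound 3 (0.20 log units; within the scatter) shows chloro and methoxy within the scatter of each other. A modest rise in the number is therefore expected for compound 4 in this assay, a 2.0-fold higher number from compound 3 to compound 4 (0.30 log units; within the scatter). The estimate for compound 4 is 320 nM, with a range from 120 nM to 900 nM.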

Compound 4, half-maximal inhibitory concentration: 690 nM
For compound 4 the middle estimate is 2.2-fold (0.33 log units) below the measured one; low and high end bracket the measured number.
By their numbers in this assay, from the lowest: compounds 1 and 3 (each within the scatter of the next); then compounds 2 and 4 (each within the scatter of the next).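

For the compounds shown here, the swap in compound 4 is the first step that changes only where the chloro sits on the benzyl group, and in this assay it gives a 4.3-fold higher number from compound 3 to compound 4 (0.63 log units; beyond the scatter), so at this position the place of the substituent matters, not just its identity. Going by these compounds alone, with a 1.7-fold higher number from compound 2 to compound 4 (0.24 log units; within the scatter), chloro and methyl read alike in the 4-substituted group, and a 6.9-fold higher number from compound 1 to compound 4 (0.84 log units; beyond the scatter) spans the two ends of the set, where compounds 1 and 3, both 3-substituted, hold the lower numbers and compounds 2 and 4, both 4-substituted, the higher, with no compound against this among the four. No measurement here accounts for this difference.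

Methoxy and methyl each appear in one place only, so whether either follows the chloro trend stays open. An unsubstituted benzyl group, or an amine or carboxylic acid on that ring, would show how far the trend extends.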